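A Benzyl Amine Swapped for an Aryl Amine

A few compounds are considered here, and "the series" means these few. Any claim that something is new, unique, unknown or untested is made for them only; others in the source may bear on it.

The study measures inhibition of gastric cancer cell growth in a functional assay on MGC-803 cells (Homo sapiens) for inhibition, read by sulforhodamine B assay; a lower number here means a stronger inhibitor, a higher number a weaker inhibitor. Two compounds share a core and differ in the group on the amine nitrogen. Compound 1 `O=C1C=C(NCc2ccccc2)C(=O)c2c1nc1n2[C@H]2OC[C@@H](O)[C@H]2OC1` carries a benzyl group and in this assay compound 1 gives 2670 nM. Compound 2 `Cc1ccc(NC2=CC(=O)c3c(nc4n3[C@H]3OC[C@@H](O)[C@H]3OC4)C2=O)cc1C` carries an aromatic ring bearing two methyl groups directly on the nitrogen, and in this assay compound 2 gives 1050 nM. Of these two numbers compound 1 shows the higher one, and the gap to compound 2 lies beyond the usual scatter of repeated measurements.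

Compound 3 `CCOc1ccccc1NC1=CC(=O)c2nc3n(c2C1=O)[C@H]1OC[C@@H](O)[C@H]1OC3` is the next compound, not yet measured. Its difference from compound 1 is 2-ethoxyphenyl in place of benzyl on an amine nitrogen. Like compound 2, compound 3 therefore places an aromatic ring directly on the amine nitrogen rather than through a methylene link. Because compound 2 gives 1050 nM where compound 1 gives 2670 nM, a step from compound 1 to compound 3 towards a lower number is expected, of modest size and beyond the scatter, namely a 2.1-fold lower number from compound 1 to compound 3 (0.31 log units; beyond the scatter). Compound 3 is estimated in this assay at 1300 nM, with a range from 500 nM to 3200 nM.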

Compound 3, half-maximal inhibitory concentration: 2450 nM
Estimate against measurement, compound 3: 1.9-fold (0.28 log units) below; low and high end bracket the measured number.
By their numbers in this assay, from the lowest: compound 2; then compounds 3 and 1 (each within the scatter of the next).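

In this assay, replacing benzyl with 2-ethoxyphenyl on the amine nitrogen gives a 1.1-fold lower number from compound 1 to compound 3 (0.04 log units; within the scatter), so placing an aromatic ring directly on that nitrogen does not by itself separate compound 3 from the benzyl compound. Compound 2 also has an aromatic ring directly on the nitrogen and gives 1050 nM, whereas compound 3 gives 2450 nM; the direct link is therefore shared by a compound with the lower number and one with a number that stays within the scatter of the benzyl compound, and the lower number of compound 2 cannot be credited to the link alone. Nothing available explains why the two aromatic groups give different numbers on the shared core.

The compounds shown leave open how an unsubstituted phenyl ring on the amine nitrogen would read in this assay, which would give a plain reference for both aromatic groups. They also leave open whether a 2-methoxyphenyl group, with its shorter chain on oxygen, or a 3-methylphenyl group with a single methyl would sit closer to compound 2 or to compound 3.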